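Bromophenol triazole series: fluoro in place of methoxy

The compounds below may be only part of what the source reports. "The series", "measured", "known", "first", "only" and "open" are said of these compounds alone.

Measured so far, in a functional assay on HL-60 cells (Homo sapiens) for cytotoxicity, read by MTT assay, with a stated time of 4 days; a higher number here means a weaker inhibitor, a lower number a stronger inhibitor:
- compound 1, `C=C1C(=O)[C@]23C[C@@]1(O)CC[C@H]2c1ccc(OS(=O)(=O)c2ccc(C)cc2)c(C)c1[C@@H]3Cn1cc(-c2ccccn2)nn1`: 1810 nM
- compound 2, `C=C1C[C@]23C[C@@]1(O)CC[C@H]2c1cc(Br)c(O)c(C)c1[C@@H]3Cn1cc(-c2ccc(OC)cc2)nn1`: reported only as a limit, > 20000 nM
- compound 3, `C=C1C[C@]23C[C@@]1(O)CC[C@H]2c1ccc(OS(=O)(=O)c2ccc(C)cc2)c(C)c1[C@@H]3Cn1cc(-c2ccc(C)cc2)nn1`: reported only as a limit, > 20000 nM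

Compound 2 carries no number in this assay , only a limit, > 20000 nM. Compound 3 likewise sits at a limit, > 20000 nM. Within the data shown here, the only numeric value belongs to compound 1, which in this assay gives 1810 nM. Compound 2 therefore stands at the upper boundary of what the assay reports, at the limit of > 20000 nM in this assay, at which 2 of the 3 values shown sit, and nothing places it relative to compound 3 beyond that shared limit.

Compound 4, `C=C1C[C@]23C[C@@]1(O)CC[C@H]2c1cc(Br)c(O)c(C)c1[C@@H]3Cn1cc(-c2ccc(F)cc2)nn1`, differs from compound 2 in one place: fluoro in place of methoxy on an aromatic carbon, that is 4-methoxyphenyl to 4-fluorophenyl. Among the measured compounds shown here, no step between two measured compounds differing in one place is available, so no size for such a change can be read from the series.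

For the measured compounds named here, with compound 2 at a limit and no measured step to lean on, the step from compound 2 to compound 4 is expected to be a number no higher from compound 2 to compound 4 (the limit leaves the size open), none beyond the scatter. Compound 4 is accordingly estimated at 20000 nM, with a range from 7000 nM to 40000 nM, and most probably this assay will again return only a limit for compound 4.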

Compound 4, half-maximal inhibitory concentration: 6600 nM
Compound 4: the middle estimate sits 3.0-fold (0.48 log units) above what was measured; the whole stated range lies above it.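

Fluoro in place of methoxy on this aromatic carbon, 4-methoxyphenyl to 4-fluorophenyl, brings in this assay an at least 3.0-fold lower number from compound 2 to compound 4 (0.48 log units; beyond the scatter). Among these compounds, this is the first single-place step that can be read, and it shows that the group at this place, para to a large group, is not indifferent: with the rest of the structure unchanged, this one exchange gives compound 4 a number, 6600 nM. The step can only be read as a minimum because compound 2 has a limit and no number: the limit of > 20000 nM in this assay, at which 2 of the 4 values shown sit.

From the compounds shown here alone, the true size of the step stays open, and so does whether the gain belongs to fluoro itself or would follow from any group other than methoxy at this place, such as chloro, an amine or a carboxylic acid. Also open, going by these compounds, is whether the same exchange would carry over to the core of compound 3, which bears the 4-methylbenzenesulfonate ester in place of the bromine and hydroxyl.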